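This account rests on a few compounds, and the source may have more. Where it says the series, first, only, none or still open, it means among the compounds named here.

Among the measured compounds shown here, compound 2 `Cc1cccc(N2C(=O)CSC2c2cccc(C(=O)NCCCCc3ccccc3)c2)c1` is the reference point of the two compounds measured so far. In a functional assay on HOS-TE85 cells (Homo sapiens) for inhibition, read by CCK-8 assay, with a stated time of 72 h, tested at 1 uM (on this read-out higher numbers stand for more inhibition at the one concentration tested (going by the name of the read-out) and lower numbers for less inhibition), compound 2 gives 96%, the highest of the two numbers; the nearest is compound 1 `COc1ccc(OC)c(N2C(=O)CSC2c2cccc(C(=O)NCCCCc3ccccc3)c2)c1`, which in this assay gives 20%. For the measured compounds named here, the single step that joins them, a number 76 percentage points higher from compound 1 to compound 2 (beyond the scatter), is large and beyond the scatter. Compound 3 `COc1cc(F)ccc1N1C(=O)CSC1c1cccc(C(=O)NCCCCc2ccccc2)c1` has not yet been measured; its change from compound 2 is 4-fluoro-2-methoxyphenyl in place of 3-methylphenyl on an amide-type nitrogen in a ring. Going by the values given here, only the step from compound 1 to compound 2 bears on this change: there the 2,5-dimethoxyphenyl on the amide-type nitrogen in a ring was replaced by 3-methylphenyl with a large gain, and in compound 3 the entering 4-fluoro-2-methoxyphenyl again carries a methoxy on that ring, as compound 1 did, while the 3-methylphenyl leaves. A loss in this assay is therefore expected, although the entering group matches neither measured ring exactly, so its size is uncertain. For compound 3 the expected step is a number 51 percentage points lower from compound 2 to compound 3 (beyond the scatter), and the estimate is 45% with a range from 15% to 80%.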

Compound 3, a percentage reported as inhibition, at one concentration (the size of the read-out at that concentration, not a potency): 94%
Compound 3: the middle estimate sits 49 percentage points below what was measured; measured number above the stated range.
By their numbers in this assay, from the lowest: compound 1; then compounds 3 and 2 (each within the scatter of the next).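

In this assay, 4-fluoro-2-methoxyphenyl and 3-methylphenyl on the amide-type nitrogen in a ring cannot be told apart, with a number 2 percentage points lower from compound 2 to compound 3 (within the scatter), so this position accepts an aromatic ring carrying a methoxy and a fluorine as well as one carrying a methyl. The large step seen earlier therefore does not follow from the presence of a methoxy on this ring alone: with a methoxy present in both groups, the exchange of 2,5-dimethoxyphenyl for 4-fluoro-2-methoxyphenyl still gives a number 74 percentage points higher from compound 1 to compound 3 (beyond the scatter), and among these compounds only the 2,5-dimethoxyphenyl group goes with the low number. No measurement at hand explains this difference.

The compounds shown do not separate the second methoxy of compound 1 from the fluorine of compound 3, since these groups also sit at different places on the ring, and they do not rank compound 2 and compound 3 at this single concentration. On these data alone, it remains open whether a ring bearing an amine or a carboxylic acid in place of the methyl, methoxy or fluorine would keep the number of compound 3 or fall towards that of compound 1.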